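This account rests on a few compounds, and the source may have more. Where it says the series, first, only, none or still open, it means among the compounds named here.

Measured so far:
- compound 1, `Cc1ccc2c(c1)[n+]([O-])c(N)n[n+]2[O-]`, solubility 3000000 nM
- compound 2, `CN(C)CCNc1n[n+]([O-])c2ccccc2[n+]1[O-]`, solubility 50000000 nM

In a physicochemical assay for solubility, in the presence of a further agent that is not named here (on this read-out higher numbers stand for higher solubility and lower numbers for lower solubility), compound 2 gives 50000000 nM, the highest of the two numbers; the nearest is compound 1 with 3000000 nM, a gap well beyond the usual scatter of repeated measurements. Compound 3, `CCCN(CCC)CCNc1n[n+]([O-])c2ccccc2[n+]1[O-]`, has not yet been measured. It differs from compound 2 in one place: dipropylamino in place of dimethylamino on a saturated chain carbon, two bonds along the chain from a nitrogen on an aromatic ring. Among the compounds with values here, no measured pair isolates this change, so nothing here shows directly how this assay answers to it. The only anchor is the high value of compound 2 itself. Because compound 2 gives 50000000 nM, compound 3 is expected to stay in a high range, but the estimate allows for a drop, with a step of a 5.0-fold lower number from compound 2 to compound 3 (0.70 log units; beyond the scatter) expected. For compound 3 the estimate in this assay is therefore 10000000 nM, within a range from 1500000 nM to 50000000 nM, a wide band reflecting how little the two measured compounds constrain this particular change.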

Compound 3, solubility: > 25000000 nM
Compound 3: a limit, no number; the forecaster's own chance of this, stated with the estimate: 10%; middle value at least 2.5-fold (0.39 log units) from the limit.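

In this assay compound 3 gives > 25000000 nM, which is a limit and not a number. No step from compound 2 to compound 3 can be read, because compound 3 has only this limit: the limit of > 25000000 nM in this assay, at which 1 of the 3 values shown sits.

The compounds shown leave open whether dipropylamino in place of dimethylamino raises, lowers or leaves unchanged the number in this assay.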